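Removing one bromo from compound 1

A few compounds are considered here, and "the series" means these few. Any claim that something is new, unique, unknown or untested is made for them only; others in the source may bear on it.

Within the data shown here, in a functional assay on HeLa cells (Homo sapiens) for cytotoxicity, read by MTT assay, with a stated time of 24 h (on this read-out higher numbers stand for weaker inhibition and lower numbers for stronger inhibition), compound 1 (`O=c1nc2ccc(Br)cn2cc1Cc1ccc(Br)cc1`) gives 931000 nM as the only actual number so far. Compound 2 (`CC1(C)OC2O[C@@H](Cc3cn4ccccc4nc3=O)C(OCc3ccccc3)C2O1`) stands at > 1000000 nM as a limit of the assay. Compound 3 (`O=c1nc2ccc(Br)cn2cc1Cc1ccccc1`) keeps the core of compound 1 and differs in one place: hydrogen in place of bromo on an aromatic carbon puts hydrogen in place of bromo on an aromatic carbon. Among the measured compounds shown here, the series holds no measured step to serve as a guide. The expected step of a 1.0-fold lower number from compound 1 to compound 3 (0.01 log units; within the scatter) stays within the scatter of this assay and has no clear direction. Compound 3 is estimated at 900000 nM with an expected range from 400000 nM to 1000000 nM if a number is reported.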

Compound 3, half-maximal inhibitory concentration: 152000 nM
Compound 3: the middle estimate sits 5.9-fold (0.77 log units) above what was measured; measured number below the stated range.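

In this assay, among these compounds, hydrogen in place of the bromo para to a large group gives a 6.1-fold lower number from compound 1 to compound 3 (0.79 log units; beyond the scatter), the first readable step. At this position, the bromo is not required for the activity seen, and its loss gives stronger inhibition. Compound 2 offers no such comparison, and its value is a limit: the limit of > 1000000 nM in this assay, at which 1 of the 3 values shown sits.

From the compounds shown here alone, what a methoxy group or an amine would give at this position stays open. So does the contribution of the remaining bromo on the core shared by compound 1 and compound 3.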